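The compounds below may be only part of what the source reports. "The series", "measured", "known", "first", "only" and "open" are said of these compounds alone.

Measured compounds in a functional assay on NCI-H460 cells (Homo sapiens) for inhibition, with a stated time of 72 h; on this read-out higher numbers stand for weaker inhibition and lower numbers for stronger inhibition:
compound 1, `COc1ccc(S(=O)(=O)N2CCc3cccc(-c4ccc([N+](=O)[O-])cc4)c32)cc1`, gives 53.1 nM
compound 2, `COc1ccc(S(=O)(=O)N2CCc3cccc(-c4ccc(C#N)cc4)c32)cc1`, gives 29.5 nM
compound 3, `COc1ccc(S(=O)(=O)N2CCc3cccc(-c4ccc(F)c(F)c4)c32)cc1`, gives 46 nM

Compound 3 sits among the other two: a 1.2-fold lower number from compound 1 to compound 3 (0.06 log units; within the scatter) and a 1.6-fold higher number from compound 2 to compound 3 (0.19 log units; within the scatter), so the three numbers cannot be told apart. Compound 4, `COc1ccc(S(=O)(=O)N2CCc3cccc(-c4ccc(N(C)C)cc4)c32)cc1`, differs from compound 3 by 4-(dimethylamino)phenyl in place of 3,4-difluorophenyl on an aromatic carbon. Among the compounds with values here, the steps that bear on this place are the three measured ones, a 1.8-fold lower number from compound 1 to compound 2 (0.26 log units; within the scatter) included; each swaps one aryl group for another at the same carbon, and none moved the number beyond the scatter. Within the data shown here, no measured compound carries 4-(dimethylamino)phenyl, so the step is expected to be a 1.0-fold lower number from compound 3 to compound 4 (0.01 log units; within the scatter), with no change beyond the scatter foreseen. Compound 4 is therefore estimated at 45 nM, range 15 nM to 140 nM; the range is kept wide, this group being absent from the measured set.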

Compound 4, half-maximal inhibitory concentration: 556 nM
Estimate against measurement, compound 4: 12-fold (1.09 log units) below, and the stated range ends below it.
By their numbers in this assay, from the lowest: compounds 2, 3 and 1 (each within the scatter of the next); then compound 4.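

This position does not tolerate every aryl group: with 4-(dimethylamino)phenyl there is a 12-fold higher number from compound 3 to compound 4 (1.08 log units; beyond the scatter) and a 19-fold higher number from compound 2 to compound 4 (1.28 log units; beyond the scatter) and a 10-fold higher number from compound 1 to compound 4 (1.02 log units; beyond the scatter) and all three point to weaker inhibition. Compounds 1, 2 and 3 stay within the scatter of one another, so compound 4 alone stands apart. Nothing measured here explains this loss.

Whether the loss is specific to dimethylamino remains open, since a primary amine or a morpholine on the same phenyl is not among the compounds shown. From the compounds shown here alone, how a methoxy group or a carboxylic acid there would read is also open.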